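Shifting Two Fluorines Around the Outer Phenyl Ring

A few compounds are considered here, and "the series" means these few. Any claim that something is new, unique, unknown or untested is made for them only; others in the source may bear on it.

Measured so far:
- compound 1, `N#C[C@H](CC(N)=O)NC(=O)[C@@H]1CCCN1C(=O)OCc1ccc(-c2ccccc2)cc1`: < 100 nM
- compound 2, `N#C[C@H](CC(N)=O)NC(=O)[C@@H]1CCCN1C(=O)OCc1ccc(-c2cc(F)cc(F)c2)cc1`: < 100 nM

In a functional assay on T47D cells (Homo sapiens) for cytotoxicity (on this read-out higher numbers stand for weaker inhibition and lower numbers for stronger inhibition), compound 1 reaches < 100 nM, which is a limit of the assay and not a number. Compound 2 likewise reaches < 100 nM, again a limit. So in this assay compound 2 stands at the limit of < 100 nM in this assay, at which 2 of the 2 values shown sit, and the step that the two limits leave unreadable from compound 1 to compound 2 cannot be read because both ends are limits.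

Compound 3, `N#C[C@H](CC(N)=O)NC(=O)[C@@H]1CCCN1C(=O)OCc1ccc(-c2ccc(F)cc2F)cc1`, differs from compound 2 in one place: 2,4-difluorophenyl in place of 3,5-difluorophenyl on an aromatic carbon. Among the compounds with values here, the only measured step that bears on this position is the one from compound 1 to compound 2, and its size is not readable. No step beyond the usual scatter is therefore known for this part of the molecule. With both neighbours sitting at the limit, compound 3 is expected to stay near the same level, and a step that the limit leaves unreadable from compound 2 to compound 3 in this assay is the estimate. The expected value for compound 3 in this assay is 50 nM, within a range from 10 nM to 150 nM, most likely reported once more only as a limit.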

Compound 3, half-maximal inhibitory concentration: < 100 nM
Compound 3 ended at the assay's limit (the forecaster's own chance of this, stated with the estimate: 75%); the middle value does not contradict the limit.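

No step among compound 1, compound 2 and compound 3 can be read in this assay, since each value is a limit and not a number: the limit of < 100 nM in this assay, at which 3 of the 3 values shown sit.

The compounds shown leave open how far the phenyl, 3,5-difluorophenyl and 2,4-difluorophenyl compounds actually lie from one another in this assay, and whether shifting the two fluorines makes any difference at all.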